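Expecting compound 4 from three measured relatives

The source may hold more compounds than are shown below. What is called first, only, known or untested is meant among the compounds shown, and "the series" means these compounds.

Three measured compounds share one core and differ only in the ring groups attached to the chain carbons. Compound 1 `COc1ccccc1/C=C1\CCC/C(=C\c2cccc(OC)c2OC)C1=O` gives 31300 nM in an ADME assay on NHDF cells (Homo sapiens) for cytotoxicity, read by MTT assay, with a stated time of 72 h; on this read-out lower numbers stand for stronger inhibition and higher numbers for weaker inhibition. Compound 2 `COc1cccc(/C=C2\CCC/C(=C\c3cc(Cl)cc(Cl)c3)C2=O)c1OC` gives 21600 nM in this assay. Compound 3 `COc1ccc(/C=C2\CCC/C(=C\c3ccc(Br)cc3)C2=O)cc1OC` gives 13100 nM in this assay; this is the lowest of the three numbers, its gap to compound 2 lying within the scatter and its gap to compound 1 lying beyond it.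

Compound 4 `COc1cc(/C=C2\CCC/C(=C\c3ccc(OC)c(OC)c3)C2=O)ccc1O` is not yet measured. It differs from compound 3 in one place: 4-hydroxy-3-methoxyphenyl in place of 4-bromophenyl on a double-bonded chain carbon bound to a double-bonded ring carbon.

For the measured compounds named here, one measured step bears on this change: a 1.4-fold lower number from compound 1 to compound 2 (0.16 log units; within the scatter). There, too, one ring group was exchanged for another on the same kind of chain carbon, and the number barely moved. The same small movement is expected here. Going by the values given here, compound 3 gives 13100 nM, the lowest number so far, so the estimate leans toward a slightly higher number rather than a lower one. The step expected from this change is a 1.4-fold higher number from compound 3 to compound 4 (0.14 log units; within the scatter). Compound 4 is thus expected to give about 18000 nM in this assay, with a range from 7000 nM to 50000 nM.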

Compound 4, half-maximal inhibitory concentration: 13700 nM
Compound 4: middle estimate off by 1.3-fold (0.12 log units), on the high side; the range from low to high includes it.
By their numbers in this assay, from the lowest: compounds 3, 4, 2 and 1 (each within the scatter of the next, the first and the last beyond it).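

In this assay, the exchange of 4-bromophenyl for 4-hydroxy-3-methoxyphenyl on a double-bonded chain carbon bound to a double-bonded ring carbon gives a 1.0-fold higher number from compound 3 to compound 4 (0.02 log units; within the scatter). For the compounds shown here, this position therefore takes a group with more heavy atoms, and with a hydrogen-bond donor and hydrogen-bond acceptors where 4-bromophenyl has none, without a shift beyond the scatter, and none of the earlier compounds carried a hydroxy group to show this. Nothing measured here explains why the number holds steady.

On these data alone, whether the same holds for a ring carrying an amine or a carboxylic acid, or for a longer chain at this position, remains open. Also open, as far as these compounds go, is what the hydroxy group contributes on its own, apart from the methoxy group on the same ring.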